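This account rests on a few compounds, and the source may have more. Where it says the series, first, only, none or still open, it means among the compounds named here.

Compound 3 `N#Cc1cccc(COc2ccc(-c3cc(CN4CCN(c5ccc(C(F)(F)F)cc5)CC4)no3)cc2)c1` gives 2700 nM in a functional assay on Mahlavu cells (Homo sapiens) for antiproliferative activity, read by sulforhodamine B assay, with a stated time of 72 h (on this read-out lower numbers stand for stronger inhibition and higher numbers for weaker inhibition), the lowest of the three numbers measured. Compound 2 `Cc1cc(C)cc(COc2ccc(-c3cc(CN4CCN(Cc5ccc(C(F)(F)F)cc5)CC4)no3)cc2)c1` gives 6000 nM in this assay, and compound 1 `FC(F)(F)c1ccc(CN2CCN(Cc3cc(-c4ccc(OCc5ccccc5)cc4)on3)CC2)cc1` gives 11700 nM; the step from compound 1 to compound 2 is a 2.0-fold lower number from compound 1 to compound 2 (0.29 log units; within the scatter). Compound 4 `N#Cc1cccc(COc2ccc(-c3cc(CN4CCN(C(=O)C5CC5)CC4)no3)cc2)c1` has not yet been measured. It differs from compound 3 in one place: cyclopropylcarbonyl in place of 4-(trifluoromethyl)phenyl on an amine nitrogen in a ring. Among the compounds with values here, the only measured step, that from compound 1 to compound 2, changes the group on the saturated chain carbon bound to the oxygen, not the group on the amine nitrogen in the ring, so it does not bear on this change, and no measured pair separates the effect of the group on that ring nitrogen. The expectation for compound 4 therefore rests on little, and the author expects a step of a 2.6-fold higher number from compound 3 to compound 4 (0.41 log units; beyond the scatter) in this assay, toward a higher number. Compound 4 is estimated at 7000 nM, within a range from 1800 nM to 28000 nM.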

Compound 4, half-maximal inhibitory concentration: 4400 nM
Compound 4: middle estimate off by 1.6-fold (0.20 log units), on the high side, and the stated range covers the measured number.
By their numbers in this assay, from the lowest: compounds 3, 4, 2 and 1 (each within the scatter of the next, the first and the last beyond it).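

In this assay, within the data shown here, the first change at the amine nitrogen in the ring gives a 1.6-fold higher number from compound 3 to compound 4 (0.21 log units; within the scatter), so this pair does not separate the two groups. For compound 3 and compound 4, then, cyclopropylcarbonyl, with 5 heavy atoms, one hydrogen-bond acceptor and no aromatic ring, stands in place of 4-(trifluoromethyl)phenyl, with 10 heavy atoms and one six-membered aromatic ring, without a step beyond the scatter. Nothing available explains why the two numbers lie so close.

The compounds shown leave open whether an acetyl group, a benzoyl group or a bare amine hydrogen on that ring nitrogen would give a step beyond the scatter from compound 3. They also leave open whether this change would read the same with the 3,5-dimethylphenyl group of compound 2 on the saturated chain carbon bound to the oxygen.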